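This account rests on a few compounds, and the source may have more. Where it says the series, first, only, none or still open, it means among the compounds named here.

Among the measured compounds shown here, in an ADME assay on the whole organism for pharmacokinetics, with Mus musculus as the target, with a stated time of 24 h, at a dose of 5 mg/kg by the oral route (a higher number here means that a larger share of the oral dose reaches the circulation, a lower number that a smaller share of the oral dose reaches the circulation), compound 1 `COc1nn(-c2ccccn2)c2cc(-c3ccc([C@H]4C[C@@H]4C(=O)O)cc3)cc(F)c12` gives 159%, the higher of the two numbers so far. Compound 2 `COc1nn(-c2ccccn2)c2cc(-c3ccc([C@H]4C[C@@H]4C(=O)O)cc3)ccc12`, with hydrogen in place of fluoro on an aromatic carbon, gives 126%. This is a number 33 percentage points lower from compound 1 to compound 2 (beyond the scatter), a large step. Compound 3 `COc1nn(-c2ccc(C)cc2)c2cc(-c3ccc([C@H]4C[C@@H]4C(=O)O)cc3)cc(F)c12` keeps the fluoro of compound 1 and changes a different place: 4-methylphenyl in place of pyridin-2-yl on an aromatic nitrogen. In words, 4-methylphenyl stands in place of pyridin-2-yl on an aromatic nitrogen. For the measured compounds named here, no measured step touches that place, so the fluoro step bears on it only loosely, showing that a single swap can move this read-out a long way. Since compound 1 starts from the top number at 159%, a fall seems likelier than a rise, though the direction remains uncertain. The expected change is a number 54 percentage points lower from compound 1 to compound 3 (beyond the scatter). For compound 3 the estimated value is 105%, within an expected range from 55% to 165%.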

Compound 3, oral bioavailability: 19%
Compound 3: the middle estimate sits 86 percentage points above what was measured, outside the stated range (below it).
By their numbers in this assay, from the lowest: compound 3; then compound 2; then compound 1.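

In this assay the group on the aromatic nitrogen of the five-membered ring carries real weight: 4-methylphenyl in place of pyridin-2-yl gives a number 140 percentage points lower from compound 1 to compound 3 (beyond the scatter) in a single swap, which is well beyond the fluoro change, a number 33 percentage points lower from compound 1 to compound 2 (beyond the scatter) on the same scale. This one swap takes out a ring nitrogen, the only hydrogen-bond acceptor of the group, and brings in a methyl group, so two things change together at this position. Nothing measured here explains the drop.

The compounds shown leave open whether the loss follows the missing ring nitrogen or the added methyl group. A plain phenyl group on that nitrogen, or a pyridin-2-yl ring carrying a methyl group, would help to tell these two apart.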